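This account rests on a few compounds, and the source may have more. Where it says the series, first, only, none or still open, it means among the compounds named here.

In a functional assay on ECa-109 cells for inhibition, with ECa-109 cell line (Homo sapiens) as the target, read by MTT assay, with a stated time of 72 h (a lower number here means a stronger inhibitor, a higher number a weaker inhibitor), compound 1 `COc1cc(/C=C/C(=O)c2ccc(OCCCSC(=S)N3CCN(C)CC3)cc2)cc(OC)c1OC` gives 7430 nM and compound 2 `COc1cc(/C=C/C(=O)c2ccc(OCCSC(=S)N3CCCC3)cc2)cc(OC)c1OC` gives 10700 nM; the step of a 1.4-fold higher number from compound 1 to compound 2 (0.16 log units; within the scatter) lies at the far end of the molecule from the double bond. Compound 3 `O=C(/C=C/c1cccnc1)c1ccc(OCCCSC(=S)N2CCCC2)cc1` gives 29800 nM in this assay, the highest of the three numbers, beyond the scatter from both compound 2 and compound 1. Compound 4 `O=C(/C=C/c1ccc(Cl)cc1)c1ccc(OCCCSC(=S)N2CCCC2)cc1` differs from compound 3 by 4-chlorophenyl in place of pyridin-3-yl on a double-bonded chain carbon bound to a double-bonded chain carbon. No measured step concerns this part of the shared core, so nothing shown tells the direction of the change. The step of a 1.7-fold lower number from compound 3 to compound 4 (0.22 log units; within the scatter) is therefore expected to be small and uncertain in direction. Compound 4 is estimated at 18000 nM, within a range of 5000 nM to 60000 nM.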

Compound 4, half-maximal inhibitory concentration: 18600 nM
Compound 4: the middle estimate sits 1.0-fold (0.01 log units) below what was measured; the range from low to high includes it.
By their numbers in this assay, from the lowest: compounds 1, 2, 4 and 3 (each within the scatter of the next, the first and the last beyond it).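

In this assay, among these compounds, the exchange of pyridin-3-yl for 4-chlorophenyl on a double-bonded chain carbon bound to a double-bonded chain carbon gives a 1.6-fold lower number from compound 3 to compound 4 (0.20 log units; within the scatter) and is the first measured step at this position. With the rest of the molecule unchanged, this assay therefore does not tell these two rings apart. No measured information bears on the reason for this result. Going by these compounds, what an amine or a carboxylic acid on the aromatic ring at this position would do remains open, as does the effect of a longer chain on the oxygen.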